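Swapping the whole aryl group: from compound 1 to compound 4

A few compounds are considered here, and "the series" means these few. Any claim that something is new, unique, unknown or untested is made for them only; others in the source may bear on it.

Measured compounds and their values in a functional assay on CHO cells for agonist activity at Free fatty acid receptor 1 (Homo sapiens), read by FLIPR and calcium flux; on this read-out lower numbers stand for an effect already at smaller amounts and higher numbers for an effect only at larger amounts of compound:
compound 1 `COc1cc(C)c(-c2cccc(COc3ccc(S(=O)(=O)CC(=O)O)cc3)c2)c(C)c1` gives 57.5 nM;
compound 2 `Cc1cc(OCC2CC2)cc(C)c1-c1cccc(COc2ccc(S(=O)(=O)CC(=O)O)cc2)c1` gives 79.4 nM;
compound 3 `COCCOc1cc(C)c(-c2cccc(COc3ccc(S(=O)(=O)CC(=O)O)cc3)c2)c(C)c1` gives 126 nM.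

All three share the same core and differ only in the group attached through an oxygen on the aromatic ring. Compound 1 carries the lowest of the three numbers, but its separation from compound 2 is small: a 1.4-fold higher number from compound 1 to compound 2 (0.14 log units; within the scatter). The step to compound 3 is somewhat larger: a 2.2-fold higher number from compound 1 to compound 3 (0.34 log units; beyond the scatter); between compound 2 and compound 3 the step is a 1.6-fold higher number from compound 2 to compound 3 (0.20 log units; within the scatter).

Compound 4 `Cc1ccc(-c2cccc(COc3ccc(S(=O)(=O)CC(=O)O)cc3)c2)c(Cl)c1` differs from compound 1 elsewhere. The change is 2-chloro-4-methylphenyl in place of 4-methoxy-2,6-dimethylphenyl on an aromatic carbon. For the measured compounds named here, none of the measured steps touches this kind of change: each of them only alters the group on the oxygen, and each of them stays small. The change to compound 4 removes that oxygen-bearing group entirely together with the two methyls flanking the ring junction, so the measured steps give no direct guide, and a broad range is appropriate. A higher number is expected for compound 4, with the step of a 5.2-fold higher number from compound 1 to compound 4 (0.72 log units; beyond the scatter), giving an estimate of 300 nM within the range 80 nM to 1200 nM.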

Compound 4, half-maximal effective concentration in the Free fatty acid receptor 1 assay: 36.3 nM
The estimate for compound 4 lay 8.3-fold (0.92 log units) above the measured number; the measured number lies below the stated range.
By their numbers in the Free fatty acid receptor 1 assay, from the lowest: compounds 4, 1, 2 and 3 (each within the scatter of the next, the first and the last beyond it).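

In the Free fatty acid receptor 1 assay, putting 2-chloro-4-methylphenyl in place of 4-methoxy-2,6-dimethylphenyl gives a 1.6-fold lower number from compound 1 to compound 4 (0.20 log units; within the scatter). The earlier compounds shown here altered only the group on the oxygen, whereas compound 4 shows that a number in the same range is kept even when the whole aryl group is exchanged, with the oxygen-bearing group and the two methyls of compound 1 gone. The exchange does show up in a physicochemical assay for lipophilicity, using the shake flask method, in phosphate buffer, measured as octanol-water partition, with a stated time of 24 h, at pH 7.4, tested at 100 uM (on this read-out lower numbers stand for lower lipophilicity and higher numbers for higher lipophilicity), where compound 1 gives 2.45 and compound 4 gives 3.05, so the two compounds are clearly apart: the measured distribution coefficient of compound 1, 2.45, and of compound 4, 3.05, a number 0.60 log units higher (beyond the scatter)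

The two aryl groups differ in several features at once, and the compounds shown do not separate what the chlorine, the methoxy and the two methyls each contribute to either read-out. Also open, as far as these compounds go, is whether an aryl group carrying an amine at this position would keep the number in the Free fatty acid receptor 1 assay in the same range while giving a distribution coefficient closer to that of compound 1.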